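The source may hold more compounds than are shown below. What is called first, only, known or untested is meant among the compounds shown, and "the series" means these compounds.

Compound 1 `CCCCCCCCC(=O)NCc1cc(Br)c(O)c(OC)c1` gives 252 nM in an assay on HEK293 cells for inhibition of transient receptor potential cation channel subfamily V member 1 (Homo sapiens); a higher number here means a weaker inhibitor, a lower number a stronger inhibitor. Compound 2 `CCCCCCCCC(=O)NCc1cc(Cl)c(O)c(OC)c1` gives 631 nM in this assay.

For the measured compounds named here, of the two measured compounds, compound 2 stands with the higher number, so it is the weaker inhibitor; its only neighbour, compound 1, lies below it by the step of a 2.5-fold higher number from compound 1 to compound 2 (0.40 log units; beyond the scatter). Compound 3 `C#Cc1cc(CNC(=O)CCCCCCCC)cc(OC)c1O` has not yet been measured. It differs from compound 2 by ethynyl in place of chloro on an aromatic carbon. Going by the values given here, only one measured step bears on this position: the exchange of bromo for chloro, which moved the number by a 2.5-fold higher number from compound 1 to compound 2 (0.40 log units; beyond the scatter), a modest change beyond the scatter. Among the compounds with values here, no measured step tests ethynyl itself, so the direction for compound 3 rests on the observation that a change at this position shifted the number modestly. For compound 3 the estimated step is a 1.6-fold lower number from compound 2 to compound 3 (0.20 log units; within the scatter), a small move back toward compound 1. Compound 3 is therefore expected to give about 400 nM in this assay, with a likely range from 150 nM to 1200 nM.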

Compound 3, half-maximal inhibitory concentration: 2740 nM
Compound 3: the middle estimate sits 6.9-fold (0.84 log units) below what was measured; measured number above the stated range.
By their numbers in this assay, from the lowest: compound 1; then compound 2; then compound 3.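

In this assay, the earlier pair showed only that one halogen exchanged for another moves the number modestly, whereas ethynyl at this position, ortho to the hydroxy group, gives a 4.3-fold higher number from compound 2 to compound 3 (0.64 log units; beyond the scatter) and, measured against bromo, an 11-fold higher number from compound 1 to compound 3 (1.04 log units; beyond the scatter) and so makes compound 3 the weakest inhibitor of the three. The position is therefore sensitive to more than a swap between halogens, and the change from bromo to ethynyl is large rather than modest. Nothing measured here accounts for the loss seen with ethynyl.

Open, on these data alone, is whether iodo would continue the order seen from chloro to bromo, and whether a methyl or a nitrile at this place would fall nearer the halogens or nearer ethynyl. Also open, as far as these compounds go, is whether ethynyl would cost as much on a compound with a longer chain.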